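Chloro for Methyl on the Fused Ring: Cytotoxicity Outlook

This account rests on a few compounds, and the source may have more. Where it says the series, first, only, none or still open, it means among the compounds named here.

Compound 3 `Cc1cccc2sc(Nn3c(-c4ccc(Cl)cc4)nnc3-c3cccnc3)nc12` stands highest of the three compounds measured in an ADME assay on MT4 cells (Homo sapiens) for cytotoxicity, read by MTT assay, with a stated time of 5 days (on this read-out lower numbers stand for higher toxicity in this test and higher numbers for lower toxicity in this test), at 36.5 ug/mL. Compound 1 `Cc1cccc2sc(Nn3c(-c4ccc([N+](=O)[O-])cc4)nnc3-c3cccnc3)nc12` gives 13.5 ug/mL in this assay, and compound 2 `O=[N+]([O-])c1ccc(-c2nnc(-c3cccnc3)n2Nc2nc3c(Cl)cccc3s2)cc1` gives 15.6 ug/mL. Compound 4 `Clc1ccc(-c2nnc(-c3cccnc3)n2Nc2nc3c(Cl)cccc3s2)cc1` differs from compound 3 by chloro in place of methyl on an aromatic carbon. The same swap has been measured once already: a 1.2-fold higher number from compound 1 to compound 2 (0.06 log units; within the scatter). The other measured change, a 2.7-fold higher number from compound 1 to compound 3 (0.43 log units; beyond the scatter), concerns a different group and does not bear on this step. Among the measured compounds shown here, with the one relevant step within the scatter, no move beyond the scatter is expected for compound 4 in this assay, so the expected step is a 1.0-fold higher number from compound 3 to compound 4 (0.02 log units; within the scatter). Compound 4 is therefore estimated at 38 ug/mL, with a range from 18 ug/mL to 80 ug/mL.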

Compound 4, half-maximal cytotoxic concentration: 27.2 ug/mL
For compound 4 the middle estimate is 1.4-fold (0.15 log units) above the measured one; measured number inside the range.
By their numbers in this assay, from the lowest: compounds 1, 2, 4 and 3 (each within the scatter of the next, the first and the last beyond it).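

In this assay, chloro in place of methyl at this position stays within the scatter on a second core as well, with a 1.3-fold lower number from compound 3 to compound 4 (0.13 log units; within the scatter), and the two readings of this change agree: the same change on two cores in this assay, a 1.2-fold higher number (0.06 log units; within the scatter) from compound 1 to compound 2 and a 1.3-fold lower number (0.13 log units; within the scatter) from compound 3 to compound 4, 1.6-fold (0.19 log units) apart, within the scatter of two such steps. Chloro in place of nitro now gives a 1.7-fold higher number from compound 2 to compound 4 (0.24 log units; within the scatter) with chloro at this position, though this step cannot be told apart from the earlier one with methyl there: the same change on two cores in this assay, a 2.7-fold higher number (0.43 log units; beyond the scatter) from compound 1 to compound 3 and a 1.7-fold higher number (0.24 log units; within the scatter) from compound 2 to compound 4, 1.6-fold (0.19 log units) apart, within the scatter of two such steps. The compounds shown leave open whether an amine or a carboxylic acid at this position would stay as close to methyl and chloro.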